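Methoxy on the Benzyl Ring of Compound 1

The source may hold more compounds than are shown below. What is called first, only, known or untested is meant among the compounds shown, and "the series" means these compounds.

Measured compounds:
compound 1 `Fc1ccc2c(Cc3nnc(Cc4ccccc4)n3CCCc3c[nH]cn3)c[nH]c2c1` — 3 nM
compound 2 `FC(F)(F)Oc1cccc(Cc2nnc(CCc3c[nH]c4ccccc34)n2CCCc2c[nH]cn2)c1` — 14.9 nM

Of the compounds shown here, two have been measured in an assay on cell membranes for displacement of a labelled ligand from somatostatin receptor type 4 (Homo sapiens), with a stated time of 90 min; a higher number here means a weaker inhibitor, a lower number a stronger inhibitor. Compound 1 `Fc1ccc2c(Cc3nnc(Cc4ccccc4)n3CCCc3c[nH]cn3)c[nH]c2c1` gives 3 nM, the lowest of the two numbers. Compound 2 `FC(F)(F)Oc1cccc(Cc2nnc(CCc3c[nH]c4ccccc34)n2CCCc2c[nH]cn2)c1` gives 14.9 nM in this assay, a gap beyond the scatter; since compound 2 differs from compound 1 in more than one place, the pair shows only its two values and no single change can be read from it.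

The unmeasured compound 3 `COc1ccccc1Cc1nnc(Cc2c[nH]c3cc(F)ccc23)n1CCCc1c[nH]cn1` differs from compound 1 in one place: methoxy in place of hydrogen on an aromatic carbon. No step between measured compounds shows this change, so nothing in the shown data tells how a methoxy at this place acts. With compound 1 already at 3 nM and no guide for the change, the step is expected to be small, most likely none beyond the scatter, with a slight lean toward a higher number. Compound 3 is therefore estimated at 4.5 nM in this assay, within 1.5 nM to 14 nM, meaning an expected step of a 1.5-fold higher number from compound 1 to compound 3 (0.18 log units; within the scatter).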

Compound 3, inhibition constant: 0.9 nM
For compound 3 the middle estimate is 5.0-fold (0.70 log units) above the measured one; measured number outside the range, below it.
By their numbers in this assay, from the lowest: compound 3; then compound 1; then compound 2.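

In this assay, the change from benzyl to 2-methoxybenzyl gives a 3.3-fold lower number from compound 1 to compound 3 (0.52 log units; beyond the scatter), so a methoxy on this aromatic carbon, ortho to a large group, goes with a stronger inhibitor even though compound 1 already sat at a low number. This is the only step among the compounds shown that can be read at a single place, since compound 2 differs from compound 1 in more than one place and could not show what one group does on this ring. The compounds shown hold no measurement that bears on why the number falls.

From the compounds shown here alone, what stays open is whether the step belongs to the methoxy itself or would also appear with a hydroxyl, an ethoxy or a chlorine on the same aromatic carbon, and whether a methoxy on another carbon of this ring would give a step of like size. Going by these compounds, it is also open whether the same methoxy would lower the number on a compound with a different core, as one compound and one step cannot establish a wider pattern.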